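Carboxy replacing tert-butyl: working notes toward compound 4

The source may report more compounds than this note shows. Statements on the series, on what has been measured and on what is new or still open speak of the compounds shown alone.

Measured so far:
- compound 2 `Oc1c(C(Nc2ccccc2)c2ccccc2)ccc2ccccc12`: 4900 nM
- compound 3 `CC(C)(C)c1ccc(NC(c2ccccc2)c2ccc3ccccc3c2O)cc1`: 5000 nM
- compound 1 `CCOC(=O)c1ccc(NC(c2ccc3cccnc3c2O)C2CCCC2)cc1`: "not determined" (no result reported)

All numbers come from an assay on isolated protein for inhibition of CAAX prenyl protease 2 (Homo sapiens), with stated times of 60 s and 60 min; on this read-out higher numbers stand for weaker inhibition and lower numbers for stronger inhibition. Compound 2 gives 4900 nM and compound 3 gives 5000 nM; the step of a 1.0-fold higher number from compound 2 to compound 3 (0.01 log units; within the scatter) is the only one available, so compound 3 stands level with compound 2 and nothing else in this assay separates the two.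

Compound 4 `O=C(O)c1ccc(NC(c2ccccc2)c2ccc3ccccc3c2O)cc1` differs from compound 3 by carboxy in place of tert-butyl on an aromatic carbon. Going by the values given here, the single measured step bears on it only indirectly: the tert-butyl that is now removed had itself made no difference when it replaced hydrogen, as a 1.0-fold higher number from compound 2 to compound 3 (0.01 log units; within the scatter) shows. For the carboxy group entering at the same place there is no comparison in the set, so the expectation for this assay rests on the flatness of that one step and carries a wide range. Compound 4 is estimated at 5000 nM, within 1500 nM to 20000 nM, which is expected to be no change at the digits printed from compound 3 to compound 4 (within the scatter).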

Compound 4, half-maximal inhibitory concentration: 4200 nM
Estimate against measurement, compound 4: 1.2-fold (0.08 log units) above; the range from low to high includes it.
By their numbers in this assay, from the lowest: compounds 4, 2 and 3 (each within the scatter of the next).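

In this assay, carboxy in place of tert-butyl gives a 1.2-fold lower number from compound 3 to compound 4 (0.08 log units; within the scatter), and carboxy in place of hydrogen gives a 1.2-fold lower number from compound 2 to compound 4 (0.07 log units; within the scatter). The place on the aromatic ring, para to a large group, has now held hydrogen, tert-butyl and carboxy without any separation in the numbers, so the flatness seen with tert-butyl is not limited to a group with no hydrogen-bond donors or acceptors. No supporting measurement bears on why the numbers stay level.

As far as these compounds go, whether this flatness holds for an amine, a sulfonamide or a longer chain at the same place remains open. The compounds shown also leave open whether any change to the rest of the shared core would move the number beyond the scatter, or would make this place matter.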